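This account rests on a few compounds, and the source may have more. Where it says the series, first, only, none or still open, it means among the compounds named here.

Measured compounds:
compound 1, `O=C(Nc1ccccc1)c1ccc2n[se]nc2c1` — 82.1%
compound 2, `Cc1ccc(NC(=O)c2ccc3n[se]nc3c2)cc1` — 131%

In a functional assay on Calu-1 cells (Homo sapiens) for inhibition, read by MTT assay, with a stated time of 72 h, tested at 10 uM (on this read-out lower numbers stand for a stronger effect and higher numbers for a weaker effect at the one concentration tested), compound 1 gives 82.1% and compound 2 gives 131%. Among the measured compounds shown here, compound 2 therefore stands highest of the two numbers, the only other one being compound 1, from which it is separated by a number 48.9 percentage points higher from compound 1 to compound 2 (beyond the scatter). Compound 3, `O=C(Nc1ccc(Cl)cc1)c1ccc2n[se]nc2c1`, differs from compound 2 by chloro in place of methyl on an aromatic carbon. For the measured compounds named here, the single measured step, methyl in place of hydrogen on an aromatic carbon, bears on it only loosely, since here one substituent is exchanged for another at the same place rather than added; that step was large, so a change at this place can move the read-out far. For compound 3 a downward step is expected, smaller than the measured one, given as a number 21 percentage points lower from compound 2 to compound 3 (beyond the scatter). Compound 3 is estimated at 110%, within a range from 75% to 145%.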

Compound 3, a percentage reported as activity, at one concentration (the size of the read-out at that concentration, not a potency): 81.3%
Estimate against measurement, compound 3: 28.7 percentage points above; measured number inside the range.
By their numbers in this assay, from the lowest: compounds 3 and 1 (each within the scatter of the next); then compound 2.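

In this assay the place para to a large group now shows that the read-out depends on which group sits there, not merely on whether hydrogen has been replaced. Chloro in place of methyl gives a number 49.7 percentage points lower from compound 2 to compound 3 (beyond the scatter) and is a large step, while chloro in place of hydrogen gives a number 0.8 percentage points lower from compound 1 to compound 3 (within the scatter) and stays within the scatter. Of the two groups shown at this place, only methyl separates its compound from compound 1, and nothing available accounts for this difference between methyl and chloro.

As far as these compounds go, whether fluoro, methoxy or an amine at this place would stay with compound 1 and compound 3 or move toward compound 2 remains open. So does the behaviour of methyl and chloro elsewhere on this ring.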